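Ring fusion on the amide nitrogen: from compound 3 to compound 4

The source may report more compounds than this note shows. Statements on the series, on what has been measured and on what is new or still open speak of the compounds shown alone.

Compound 3 `Cc1nc(NC(=O)CN2CCN(c3ccc(F)cc3)CC2)sc1C` was measured in a physicochemical assay for lipophilicity, in phosphate buffer, measured as octanol-water partition, at pH 7.4 (on this read-out higher numbers stand for higher lipophilicity and lower numbers for lower lipophilicity), and gave 3.7. Among the numbers at hand it stands lowest; its nearest neighbour is compound 1 `O=C(CN1CCN(c2ccc(F)cc2)CC1)Nc1nc2c(s1)CCCCC2`, which in this assay gave 5, a gap beyond the usual scatter. For compound 2 `O=C(CN1CCN(c2cccc(F)c2)CC1)Nc1nc2c(s1)CCCC2` this assay returned "not determined" (no result reported). Compound 4 `O=C(CN1CCN(c2ccc(F)cc2)CC1)Nc1nc2c(s1)CCC2` has not yet been measured. It differs from compound 3 in one place: a group of 8 heavy atoms (6 carbon, 1 nitrogen, 1 sulfur; one five-membered non-aromatic ring of carbon only, one five-membered aromatic ring with 2 hetero atoms) in place of a group of 7 heavy atoms (5 carbon, 1 nitrogen, 1 sulfur; one five-membered aromatic ring with 2 hetero atoms), on an amide-type nitrogen. Going by the values given here, no directly comparable step among the measured compounds is available, so the expectation rests on the values of compound 3 and compound 1 alone. Because compound 1 gave 5, an upward step is expected, and the estimated move a number 0.50 log units higher from compound 3 to compound 4 (beyond the scatter) is modest but beyond the scatter. Compound 4 is thus expected to give about 4.2, within a range from 3.7 to 4.7.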

Compound 4, distribution coefficient: 4
Compound 4: middle estimate off by 0.20 log units, on the high side; measured number inside the range.
By their numbers in this assay, from the lowest: compounds 3 and 4 (each within the scatter of the next); then compound 1.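

On the amide-type nitrogen, exchanging the 4,5-dimethyl-1,3-thiazol-2-yl group for the group that adds a five-membered non-aromatic ring of carbon only gives a number 0.30 log units higher from compound 3 to compound 4 (within the scatter) in this assay. Going by these compounds alone, this is the first single-place step available at this position, and it shows that this added ring does not separate the two compounds on this read-out. Nothing at hand offers a measured explanation for the result. The compounds shown leave open how a group bearing an amine or a carboxylic acid would read at this position.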